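The source may hold more compounds than are shown below. What is called first, only, known or untested is meant among the compounds shown, and "the series" means these compounds.

Working notes on the series, following the step from compound 3 to compound 4. In an ADME assay on Vero cells (Chlorocebus sabaeus) for cytotoxicity, with a stated time of 7 days (a higher number here means that more compound is tolerated, a lower number that less compound is tolerated), compound 1 `COc1ccc2[nH]c(C(=O)N3CC(=O)N(Cc4c[nH]c5ccccc45)[C@@H](Cc4ccccc4)C3)cc2c1` gives 7200 nM. Compound 2 `COc1ccc2[nH]c(C(=O)N3CC(=O)N(Cc4ccccc4)[C@@H](COC(C)(C)C)C3)cc2c1` gives 78200 nM in this assay. Compound 3 `COc1ccc2[nH]c(C(=O)N3CC(=O)N(Cc4ccccc4)[C@@H](N4CCc5ccccc54)C3)cc2c1` reaches only the limit of this assay, > 100000 nM, so no number is known for it. Among the compounds with values here, the single one-point step among the measured compounds is an at least 1.2-fold higher number from compound 2 to compound 3 (0.10 log units; that floor lies within the scatter); it runs into the limit (the limit of > 100000 nM in this assay, at which 1 of the 3 values shown sits), so its true size stays open, and the floor stated for it lies within the scatter.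

Compound 4 `COc1ccc2[nH]c(C(=O)N3CC(=O)N(Cc4ccccc4)[C@@H](CN4CCc5ccccc5C4)C3)cc2c1` is not yet measured. It differs from compound 3 by (1,2,3,4-tetrahydroisoquinolin-2-yl)methyl in place of 2,3-dihydro-1H-indol-1-yl on a saturated ring carbon. Within the data shown here, no measured step exchanges either of these two groups, so the one measured step bears on it only loosely: it shows that the saturated ring carbon in question tolerates at least one large group at the high end of the range, while compound 1 sits far lower in this assay. A number near the upper part of the range is therefore expected for compound 4, with the limit a real possibility. The estimate for compound 4 is 60000 nM, between 20000 nM and 100000 nM. The expected step is an at least 1.6-fold lower number from compound 3 to compound 4 (0.22 log units; that floor lies within the scatter). With compound 3 only a limit, the size of that step is uncertain.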

Compound 4, half-maximal cytotoxic concentration: 51800 nM
Estimate against measurement, compound 4: 1.2-fold (0.06 log units) above, and the stated range covers the measured number.
By their numbers in this assay, from the lowest: compound 1; then compounds 4 and 2 (each within the scatter of the next). At a limit, above all of these: compound 3.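

In this assay, within the data shown here, compound 4 gives a real number, 51800 nM, for a group with a ring nitrogen on this saturated ring carbon, which the earlier compounds did not provide. Set against the group without a ring nitrogen, the change reads as a 1.5-fold lower number from compound 2 to compound 4 (0.18 log units; within the scatter), so 1,2,3,4-tetrahydroisoquinolin-2-yl and tert-butoxy on the saturated chain carbon bound to a saturated ring carbon cannot be told apart in this assay. The value of compound 3 is a limit, so the exchange of 2,3-dihydro-1H-indol-1-yl for (1,2,3,4-tetrahydroisoquinolin-2-yl)methyl reads only as an at least 1.9-fold lower number from compound 3 to compound 4 (0.28 log units; that floor lies within the scatter), and its true size stays open: the limit of > 100000 nM in this assay, at which 1 of the 4 values shown sits.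

The compounds shown leave open whether the saturated chain carbon or the change of ring size matters in that exchange, since (2,3-dihydro-1H-indol-1-yl)methyl on the same carbon does not appear among them. They also leave open how a primary amine or a carboxylic acid on the saturated chain carbon, or a small group such as methyl on the saturated ring carbon, would read in this assay.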